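The compounds below may be only part of what the source reports. "The series", "measured", "known", "first", "only" and "open" are said of these compounds alone.

Measured in a functional assay on HCT-116 cells (Homo sapiens) for inhibition, read by sulforhodamine B assay, with a stated time of 3 days; a lower number here means a stronger inhibitor, a higher number a weaker inhibitor:
- Compound 1 `O=C1Nc2ccc(F)cc2/C1=C\C(=O)c1ccc[nH]1`: 1380 nM
- Compound 2 `CN1CCN(c2cccc(N/C=C3\C(=O)Nc4ccc(NC(=O)c5cccc(F)c5)cc43)c2)CC1`: 2740 nM

Compound 2, at 2740 nM, stands within the usual scatter of compound 1, so these numbers do not separate the two, even though their structures differ in more than one place.

Compound 3 `CN1CCC(C(=O)Nc2ccc3c(c2)/C(=C/Nc2cccc(N4CCN(C)CC4)c2)C(=O)N3)CC1` has not yet been measured. It keeps the rest of compound 2 but carries 1-methylpiperidin-4-yl in place of 3-fluorophenyl on a carbonyl carbon whose other neighbour is an amide-type nitrogen. The change counts as follows: 1-methylpiperidin-4-yl in place of 3-fluorophenyl on a carbonyl carbon.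

Among the measured compounds shown here, no pair of measured compounds differs in only one place, so the data offer no direct guide to the effect of this exchange. Nothing measured points to a direction, and no step beyond the scatter is expected in this assay. The closest anchor is compound 2 at 2740 nM, and the range is kept wide to reflect how little is known. The expected step is a 1.1-fold lower number from compound 2 to compound 3 (0.04 log units; within the scatter). Compound 3 is estimated at 2500 nM, with an expected range of 800 nM to 8000 nM.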

Compound 3, half-maximal inhibitory concentration: 4670 nM
Compound 3: the middle estimate sits 1.9-fold (0.27 log units) below what was measured; low and high end bracket the measured number.
By their numbers in this assay, from the lowest: compounds 1, 2 and 3 (each within the scatter of the next, the first and the last beyond it).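

Among the compounds shown here, the exchange of 3-fluorophenyl for 1-methylpiperidin-4-yl on a carbonyl carbon whose other neighbour is an amide-type nitrogen gives the first comparison in this assay between compounds that differ in one place, and it reads as a 1.7-fold higher number from compound 2 to compound 3 (0.23 log units; within the scatter) for this pair. At this position, an aromatic ring of carbon only and a non-aromatic ring with one hetero atom, each with the same count of heavy atoms, are therefore not separated by this assay, and this single pair supports no wider pattern. No supporting measurement is available to explain this result.

The compounds shown leave open how other groups would read on this carbonyl carbon, such as an unsubstituted phenyl, a morpholine, a dimethylamino chain or a carboxylic acid, any of which could show whether this position can produce a step beyond the scatter. They also leave open whether the same exchange would read alike if the 3-(4-methylpiperazin-1-yl)phenyl group shared by compound 2 and compound 3 gave way to a plain phenyl.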